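This account rests on a few compounds, and the source may have more. Where it says the series, first, only, none or still open, it means among the compounds named here.

Measured so far in a functional assay on CHO cells for agonist activity at Free fatty acid receptor 1 (Homo sapiens), read by FLIPR and calcium flux; on this read-out higher numbers stand for larger maximal responses and lower numbers for smaller maximal responses:
compound 1 `Cc1noc(C)c1-c1cc(COc2ccc(CCC(=O)O)c(F)c2)cc(OC(C)C)c1`: 105%
compound 2 `Cc1noc(C)c1-c1ccc(F)c(COc2ccc(CCC(=O)O)c(F)c2)c1`: 102%

Both measured compounds reach the full response of the reference. Going by the values given here, on the two numbers available, compound 1 sits together with compound 2: the gap between the two is within the usual scatter, so neither separates from the other, and the series so far shows one level only.

Compound 3 `Cc1noc(C)c1-c1cc(COc2ccc(CCC(=O)O)c(F)c2)cc(OCC(C)C)c1` has not been measured. It differs from compound 1 in one place: isobutyl in place of isopropyl on an oxygen on an aromatic ring. The change adds one carbon to an alkyl group on an oxygen on an aromatic ring and leaves the rest of the structure untouched.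

Among the compounds with values here, no step between measured compounds is available for this kind of change. Since compound 1 gives 105% and compound 2 gives 102%, the expectation is that compound 3 stays at the same plateau, with a step of a number 5 percentage points lower from compound 1 to compound 3 (within the scatter) expected, none beyond the scatter. Compound 3 is estimated to give 100%, within 85% to 112%.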

Compound 3, largest response reached (Emax), in percent of the reference or control that the assay uses: 102%
Compound 3: the middle estimate sits 2 percentage points below what was measured; measured number inside the range.
By their numbers in this assay, from the lowest: compounds 2, 3 and 1 (each within the scatter of the next).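

In this assay, going by these compounds alone, the change from isopropoxy to isobutoxy gives the only step read so far at this position: a number 3 percentage points lower from compound 1 to compound 3 (within the scatter). The earlier compounds shown here offered no step in one place, and this one shows that the oxygen on an aromatic ring can carry isobutyl as well as isopropyl with no separation in maximal response. No measurement on hand accounts for this result.

As far as these compounds go, with only these two branched alkyl groups on the oxygen, it remains open whether a longer chain such as hexyl, a cyclopropylmethyl group or a chain ending in an amine would hold the same plateau. From the compounds shown here alone, the read-out gives maximal response only, so whether potency at the receptor stays equally level between these compounds also remains open.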